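The source may report more compounds than this note shows. Statements on the series, on what has been measured and on what is new or still open speak of the compounds shown alone.

Measured compounds:
- compound 1 `CCCc1nc(CC)c(C(=O)OCCC[S+]([O-])c2ccccc2)n1Cc1ccc(-c2ccccc2S(=O)(=O)NC(=O)OCCC(C)C)cc1F`: 1 nM
- compound 2 `CCCc1nc(CC)c(C(=O)OCCCN2C(=O)c3ccccc3C2=O)n1Cc1ccc(-c2ccccc2S(=O)(=O)NC(=O)OCCC(C)C)cc1F`: 3 nM
- compound 3 `CCCc1nc(CC)c(C(=O)OCc2cccc(C(=O)N(c3ccccc3)c3ccccc3)c2)n1Cc1ccc(-c2ccccc2-c2nn[nH]n2)cc1`: 300 nM

Among the measured compounds shown here, in an assay on isolated protein for binding affinity to Type-2 angiotensin II receptor (Homo sapiens) (a lower number here means a stronger inhibitor, a higher number a weaker inhibitor), compound 1 gives the lowest of the three numbers; compound 2 sits nearest with a 3.0-fold higher number from compound 1 to compound 2 (0.48 log units; beyond the scatter), and compound 3 lies far off, its value and that of compound 1 differing by a wide margin, though the two structures differ in several places and no single step connects them.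

Compound 4 `CCCc1nc(CC)c(C(=O)NCCCOc2ccccc2)n1Cc1ccc(-c2ccccc2S(=O)(=O)NC(=O)OCCC(C)C)cc1F` is the next one to be measured. It differs from compound 1 in one place: a group of 11 heavy atoms (9 carbon, 1 nitrogen, 1 oxygen; one six-membered aromatic ring of carbon only) in place of a group of 12 heavy atoms (9 carbon, 2 oxygen, 1 sulfur; one six-membered aromatic ring of carbon only), on a carbonyl carbon. For the measured compounds named here, the only measured step that bears on this is the one from compound 1 to compound 2, where exchanging the group on the saturated chain carbon cost a modest amount. The change in compound 4 is of a similar kind but sits on the carbonyl carbon itself, so a modest weakening beyond the scatter is the expectation, not a large one. Compound 4 is therefore estimated at 3 nM (range 1 nM to 15 nM), which would mean an expected step of a 3.0-fold higher number from compound 1 to compound 4 (0.48 log units; beyond the scatter).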

Compound 4, half-maximal inhibitory concentration: 9 nM
The estimate for compound 4 lay 3.0-fold (0.48 log units) below the measured number, and the stated range covers the measured number.
By their numbers in this assay, from the lowest: compound 1; then compound 2; then compound 4; then compound 3.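

In this assay, among the compounds shown here, the step at the carbonyl carbon, a 9.0-fold higher number from compound 1 to compound 4 (0.95 log units; beyond the scatter), lies beyond the scatter, so the group on this carbon affects the number and not only the far end of the chain, the sole site of the change in a 3.0-fold higher number from compound 1 to compound 2 (0.48 log units; beyond the scatter). The (3-phenoxypropyl)amino group carries a hydrogen-bond donor that the group it replaces lacks, and it changes both the atom attached to the carbonyl carbon and the end of the chain in one step. Nothing available explains the higher number of compound 4.

Which of these two changes accounts for the step remains open; a 3-phenoxypropyl ester on the same core would separate them. On these data alone, the effect of a carboxylic acid or a longer chain at the carbonyl carbon also remains unknown.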